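Replacing the pyridyl ring in a hydroxamic acid triazole series

The compounds below may be only part of what the source reports. "The series", "measured", "known", "first", "only" and "open" are said of these compounds alone.

In an assay on Sf9 cells for inhibition of protein deacetylase HDAC6 (Homo sapiens), read by fluorescence, with a stated time of 40 min, tested at 100 nM (on this read-out higher numbers stand for more inhibition at the one concentration tested (going by the name of the read-out) and lower numbers for less inhibition), the three measured compounds share one core, a hydroxamic acid linked through an aminomethyl bridge to a triazole that carries a phenyl group. Compound 1 `Cc1ccc(-c2nc(CNc3ccc(C(=O)NO)cc3)n(-c3ccccc3)n2)cc1` gives 62.2%, and compound 2 `O=C(NO)c1ccc(NCc2nc(-c3ccc(F)cc3)nn2-c2ccccc2)cc1` gives 70.9%; the step of a number 8.7 percentage points higher from compound 1 to compound 2 (within the scatter) lies within the scatter. Compound 3 `O=C(NO)c1ccc(NCc2nc(-c3ccncc3)nn2-c2ccccc2)cc1` gives 30.8% and stands lowest of the three, with the step of a number 31.4 percentage points lower from compound 1 to compound 3 (beyond the scatter) and the step of a number 40.1 percentage points lower from compound 2 to compound 3 (beyond the scatter) both beyond the scatter. Compound 4 `Cc1ccsc1-c1nc(CNc2ccc(C(=O)NO)cc2)n(-c2ccccc2)n1` differs from compound 3 in one place: 3-methylthiophen-2-yl in place of pyridin-4-yl on an aromatic carbon. Both measured steps into compound 3 show that the pyridin-4-yl group goes with a large drop in this assay compared with the two substituted phenyl groups. Compound 4 removes that group and brings in another aromatic ring, so compound 4 is expected to regain a good part of that loss, with an estimated step of a number 24.2 percentage points higher from compound 3 to compound 4 (beyond the scatter). Compound 4 is estimated at 55%, within a range from 35% to 75%.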

Compound 4, a percentage reported as inhibition, at one concentration (the size of the read-out at that concentration, not a potency): 72.1%
Estimate against measurement, compound 4: 17.1 percentage points below; measured number inside the range.
By their numbers in this assay, from the lowest: compound 3; then compounds 1, 2 and 4 (each within the scatter of the next).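

The step of a number 41.3 percentage points higher from compound 3 to compound 4 (beyond the scatter) shows that the low number of compound 3 does not come with every ring containing a hetero atom at this aromatic carbon, since 3-methylthiophen-2-yl, with the same count of heavy atoms as pyridin-4-yl, does not share it. The steps of a number 1.2 percentage points higher from compound 2 to compound 4 (within the scatter) and a number 9.9 percentage points higher from compound 1 to compound 4 (within the scatter) leave 3-methylthiophen-2-yl indistinguishable from 4-fluorophenyl and 4-methylphenyl in this assay, so a five-membered aromatic ring serves here as well as the two substituted six-membered ones. Among these four compounds, only pyridin-4-yl stands apart. From the compounds shown here alone, whether the methyl group on the thiophene ring contributes, and how a plain thiophen-2-yl, a pyridin-3-yl, or a phenyl ring carrying an amine or a carboxylic acid would read at this position, stays open. Nothing shown here accounts for why pyridin-4-yl differs from the other three groups.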